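The source may hold more compounds than are shown below. What is called first, only, known or untested is meant among the compounds shown, and "the series" means these compounds.

Measured compounds:
Compound 1 `NS(=O)(=O)c1ccc(COc2ccc(CNC(=O)[C@@H]3CCC(=O)N3Cc3ccccc3)cc2)cc1`: in an assay on HEK293 cells for inhibition of Ataxin-2 (Mus musculus), read by fluorescence and Amplex Red (on this read-out lower numbers stand for stronger inhibition and higher numbers for weaker inhibition), compound 1 gives > 5000 nM, which is a limit of the assay and not a number.
Compound 2 `NS(=O)(=O)c1ccc(COc2ccc(CNC(=O)[C@@H]3CCC(=O)N3Cc3ccc(F)cc3)cc2)cc1`: in this assay compound 2 gives > 5000 nM, again only a limit.

Both recorded values sit at the limit of > 5000 nM in this assay, at which 2 of the 2 values shown sit, so compound 1 has no exact position on the scale, only a limit. Among the measured compounds shown here, the single measured step, a step that the two limits leave unreadable from compound 1 to compound 2, is of unreadable size for that reason. Compound 3, `O=C(NCc1ccc(O)cc1)[C@@H]1CCC(=O)N1Cc1ccccc1`, differs from compound 1 by hydrogen in place of 4-sulfamoylbenzyl on an oxygen on an aromatic ring. For the measured compounds named here, no measured step touches this change, so no direction or size can be read for it in this assay. Compound 3 is expected to remain weak, estimated at 8000 nM with a range from 2000 nM to 40000 nM. The expected step that the limit leaves unreadable from compound 1 to compound 3 is thus itself little more than a guess.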

Compound 3, half-maximal inhibitory concentration: > 5000 nM
Compound 3: only a limit was reported (the forecaster's own chance of this, stated with the estimate: 80%); the middle value lies beyond the limit too.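

No step can be read between compound 1 and compound 3, because each value is only a limit of the assay: the limit of > 5000 nM in this assay, at which 3 of the 3 values shown sit. Left open is how strong compound 1, compound 2 and compound 3 truly are in this assay and whether replacing 4-sulfamoylbenzyl with hydrogen changes inhibition at all.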